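This account rests on a few compounds, and the source may have more. Where it says the series, first, only, none or still open, it means among the compounds named here.

Compound 1 `O=C1C=C(NCc2ccccc2)C(=O)c2c1nc1n2[C@H]2OC[C@@H](O)[C@H]2OC1`: 2670 nM
Compound 2 `O=C1C=C(Nc2ccccc2F)C(=O)c2c1nc1n2[C@H]2OC[C@@H](O)[C@H]2OC1`: 2080 nM
Compound 3 `O=C1C=C(Nc2ccc(C(F)(F)F)cc2)C(=O)c2c1nc1n2[C@H]2OC[C@@H](O)[C@H]2OC1`: 2820 nM

These three compounds share one core and differ in the group on the amine nitrogen. All three were tested in a functional assay on MGC-803 cells (Homo sapiens) for inhibition, read by sulforhodamine B assay; on this read-out lower numbers stand for stronger inhibition and higher numbers for weaker inhibition. Compound 3 gives 2820 nM, which does not set it apart from the other two: the measured steps are a 1.1-fold higher number from compound 1 to compound 3 (0.02 log units; within the scatter) and a 1.4-fold higher number from compound 2 to compound 3 (0.13 log units; within the scatter).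

Compound 4 `O=C1C=C(Nc2ccc(I)cc2)C(=O)c2c1nc1n2[C@H]2OC[C@@H](O)[C@H]2OC1` keeps the core of compound 3 and exchanges one group, iodo in place of trifluoromethyl on an aromatic carbon. For the measured compounds named here, no measured step makes this exact exchange. The closest evidence is the exchanges of the whole group on the amine nitrogen, a 1.1-fold higher number from compound 1 to compound 3 (0.02 log units; within the scatter), a 1.4-fold higher number from compound 2 to compound 3 (0.13 log units; within the scatter) and a 1.3-fold lower number from compound 1 to compound 2 (0.11 log units; within the scatter). All of these stayed small, so no step beyond the scatter is expected in this assay, and no direction is favoured. The estimate amounts to a 1.2-fold lower number from compound 3 to compound 4 (0.07 log units; within the scatter). The expected value for compound 4 is 2400 nM, with an estimated range from 1000 nM to 5000 nM.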

Compound 4, half-maximal inhibitory concentration: 1400 nM
The estimate for compound 4 lay 1.7-fold (0.23 log units) above the measured number; low and high end bracket the measured number.
By their numbers in this assay, from the lowest: compounds 4, 2, 1 and 3 (each within the scatter of the next).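

In this assay, the exchange of trifluoromethyl for iodo on the aromatic carbon gives a 2.0-fold lower number from compound 3 to compound 4 (0.30 log units; within the scatter); this is the first step shown that changes only the substituent on the six-membered aromatic ring, and it stays within the scatter. The exchanges of the whole group on the amine nitrogen, a 1.5-fold lower number from compound 2 to compound 4 (0.17 log units; within the scatter) and a 1.9-fold lower number from compound 1 to compound 4 (0.28 log units; within the scatter), also stay within the scatter, so 4-iodophenyl is not separated from 2-fluorophenyl or benzyl at this position. Nothing shown gives a measured basis for explaining these numbers.

The compounds shown leave open whether a carboxylic acid, a primary amine or a methoxy group on that aromatic carbon would give a step beyond the scatter. They also leave open how a longer chain on the amine nitrogen would read in this assay.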